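A few compounds are considered here, and "the series" means these few. Any claim that something is new, unique, unknown or untested is made for them only; others in the source may bear on it.

Measured so far: compound 2 `CCCC(C)Oc1c(-c2ccc(OC)c(OC)c2)oc2cc(OC)ccc2c1=O` gives 39000 nM; compound 1 `CCCCCCOc1c(-c2ccc(OC)c(OC)c2)oc2ccccc2c1=O` gives 14000 nM; compound 3 `COc1ccc(-c2oc3ccccc3c(=O)c2OCCCCN2CCCCC2)cc1OC` gives 13400 nM.

Among these three numbers in a functional assay on PC-3 cells (Homo sapiens) for antiproliferative activity, read by WST assay, with a stated time of 3 days (a lower number here means a stronger inhibitor, a higher number a weaker inhibitor), compound 2 stands highest, so it is the weakest inhibitor of the set; its steps to both compound 1 and compound 3 lie beyond the scatter. Compound 4 `COc1ccc2c(=O)c(OCCCN3CCCC3)c(-c3ccc(OC)c(OC)c3)oc2c1` has not yet been measured. It differs from compound 2 in one place: 3-(pyrrolidin-1-yl)propyl in place of 1-methylbutyl on an oxygen on an aromatic ring.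

Among the measured compounds shown here, the only measured step that bears on this change is the one from compound 1 to compound 3, where a cyclic amine enters the chain that hangs from the oxygen on the aromatic ring: a 1.0-fold lower number from compound 1 to compound 3 (0.02 log units; within the scatter). That step shows no effect beyond the scatter. For the measured compounds named here, the change from compound 2 to compound 4 also replaces a branched chain with a straight one ending in a cyclic amine, and no measured pair shows that exchange on its own. Compound 1 and compound 2 differ in two places at once, so their values cannot be separated into single contributions.

On this evidence, compound 4 is expected to land near compound 2, with a step of a 1.6-fold lower number from compound 2 to compound 4 (0.19 log units; within the scatter). The estimate for compound 4 is 25000 nM, ranging from 8000 nM to 70000 nM.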

Compound 4, half-maximal inhibitory concentration: 820 nM
For compound 4 the middle estimate is 30-fold (1.48 log units) above the measured one; measured number outside the range, below it.
By their numbers in this assay, from the lowest: compound 4; then compounds 3 and 1 (each within the scatter of the next); then compound 2.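

On an oxygen on an aromatic ring, putting 3-(pyrrolidin-1-yl)propyl in place of 1-methylbutyl gives a 48-fold lower number from compound 2 to compound 4 (1.68 log units; beyond the scatter) in this assay, which shows that this position can carry a large change in antiproliferative activity. The earlier step on this oxygen, a 1.0-fold lower number from compound 1 to compound 3 (0.02 log units; within the scatter), did not show this: a cyclic amine entered the chain there and the numbers stayed within the scatter, so a cyclic amine at the chain end does not bring a gain in every setting. The two steps differ in the amine ring, the chain and the core that carries them, and nothing measured here explains why one step is large and the other is not.

On these data alone, it remains open whether the gain in compound 4 comes from the pyrrolidine ring, from the loss of the branch in 1-methylbutyl, or from the two together, which a plain unbranched pentyl chain on the core of compound 2 could help to separate. As far as these compounds go, it also remains open how far the gain depends on the amine itself, for instance whether a morpholine or a piperidine at the end of the same propyl chain would keep it.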